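Swapping a Fluorinated Ring on a Shared Core

This account rests on a few compounds, and the source may have more. Where it says the series, first, only, none or still open, it means among the compounds named here.

Compound 1 `CCC1C(=O)N(C)c2cnc(-n3ccnc3-c3ccc(F)cc3)nc2N1C1CCC(F)(F)C1` was examined in an ADME assay on microsomes from liver (Rattus norvegicus) for metabolic stability, with a stated time of 30 min, tested at 1 uM (a higher number here means that more of the compound is left, a lower number that less of the compound is left), and compound 1 gives 8%. Its two companions are compound 2 `CC[C@@H]1C(=O)N(C)c2cnc(-n3ccnc3-c3ccccc3)nc2N1[C@@H]1CCOC1` with 0% and compound 3 `CC[C@@H]1C(=O)N(C)c2cnc(-c3cn[nH]c3-c3ccc(F)cc3F)nc2N1c1cnn(C)c1` with 13%; both numbers lie within the usual scatter of that of compound 1, so none of the three can be separated from the others. Compound 4 `CCC1C(=O)N(C)c2cnc(-n3ccnc3-c3ccc(F)cc3)nc2N1c1ccc(F)cc1` keeps the core of compound 1 and differs in one place: 4-fluorophenyl in place of 3,3-difluorocyclopentyl on a nitrogen on an aromatic ring in a ring. Among the compounds with values here, no measured pair shows what such an exchange does here, so no step beyond the scatter is expected; the estimate for the step of a number 2 percentage points higher from compound 1 to compound 4 (within the scatter) rests on the low numbers of compounds 1, 2 and 3. Compound 4 is expected to give about 10%, between 0% and 30%.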

Compound 4, percent of the compound remaining in the Rattus norvegicus assay: 11%
Estimate against measurement, compound 4: 1 percentage points below; measured number inside the range.
By their numbers in the Rattus norvegicus assay, from the lowest: compounds 2, 1, 4 and 3 (each within the scatter of the next, the first and the last beyond it).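

In the Rattus norvegicus assay, the first exchange read at this nitrogen, 4-fluorophenyl in place of 3,3-difluorocyclopentyl, gives a number 3 percentage points higher from compound 1 to compound 4 (within the scatter), so an aromatic and a non-aromatic ring here cannot be told apart, and both compounds stay low. In a physicochemical assay for lipophilicity (on this read-out higher numbers stand for higher lipophilicity and lower numbers for lower lipophilicity), compound 1 gives 3.1 and compound 4 gives 3.4, which is a number 0.30 log units higher from compound 1 to compound 4 (within the scatter). Nothing given here explains these numbers. Still open, going by these compounds, is whether a group carrying an amine or a carboxylic acid in this place would leave more compound in the Rattus norvegicus assay.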